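Trimming the Aryl Group on the Ring Nitrogen

The compounds below may be only part of what the source reports. "The series", "measured", "known", "first", "only" and "open" are said of these compounds alone.

Compound 1 `COc1cc2ncnc(Nc3ccc(F)cc3)c2cc1OCCCCC(=O)Nc1ccc(S(N)(=O)=O)cc1`, compound 2 `COc1ccc(Nc2ncnc3cc(OC)c(OCCCCC(=O)Nc4ccc(S(N)(=O)=O)cc4)cc23)cc1` and compound 3 `COc1ccc(Nc2ncnc3cc(OC)c(OCCCCC(=O)Nc4ccc(S(N)(=O)=O)cc4)cc23)cc1OC` share one core and differ only in the aryl group carried on the nitrogen attached to it. In a functional assay on A549 cells (Homo sapiens) for antiproliferative activity, read by MTT assay, with a stated time of 72 h (a higher number here means a weaker inhibitor, a lower number a stronger inhibitor), compound 1 gives only a limit, > 40000 nM. Compound 2 likewise reaches only a limit, > 40000 nM. Compound 3 also stops at a limit, > 40000 nM. Hence the steps a step that the two limits leave unreadable from compound 1 to compound 2, a step that the two limits leave unreadable from compound 1 to compound 3 and a step that the two limits leave unreadable from compound 2 to compound 3 cannot be sized because of the limit of > 40000 nM in this assay, at which 3 of the 3 values shown sit. Compound 4 `COc1ccccc1Nc1ncnc2cc(OC)c(OCCCCC(=O)Nc3ccc(S(N)(=O)=O)cc3)cc12` differs from compound 3 by 2-methoxyphenyl in place of 3,4-dimethoxyphenyl on a nitrogen on an aromatic ring. The measured steps give no readable size, so no direction beyond the scatter of this assay can be foreseen. Compound 4 is therefore expected to give about 60000 nM, between 20000 nM and 200000 nM, most likely once more as a limit. The expected step is a step that the limit leaves unreadable from compound 3 to compound 4.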

Compound 4, half-maximal inhibitory concentration: 24100 nM
For compound 4 the middle estimate is 2.5-fold (0.40 log units) above the measured one; the measured number falls inside the stated range.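

Among these compounds, compound 4, with 2-methoxyphenyl on the nitrogen, is the only one of the four compounds to give a number rather than a limit in this assay, so a change at this position can bring a reading into the measurable range. The steps are an at least 1.6-fold lower number from compound 3 to compound 4 (0.22 log units; that floor lies within the scatter), an at least 1.6-fold lower number from compound 2 to compound 4 (0.22 log units; that floor lies within the scatter) and an at least 1.6-fold lower number from compound 1 to compound 4 (0.22 log units; that floor lies within the scatter). Each is only a floor, and the true size of the steps stays unknown: the limit of > 40000 nM in this assay, at which 3 of the 4 values shown sit.

As far as these compounds go, it remains open whether an aminophenyl or a chlorophenyl group on this nitrogen would also give a number. From the compounds shown here alone, it is also open whether a longer chain on compound 4 would change its reading.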